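One aromatic swap in a growth-inhibition series

The compounds below may be only part of what the source reports. "The series", "measured", "known", "first", "only" and "open" are said of these compounds alone.

Compound 1 `Cc1ccsc1/C=C(/SCc1ccc(Cl)cc1)C(=O)c1ccc(Cl)cc1`: 50000 nM
Compound 2 `O=C(/C(=C\c1ccc(OCc2ccccc2)cc1)SCc1ccc(Cl)cc1)c1ccc(Cl)cc1`: 1000 nM
Compound 3 `O=C(/C(=C\c1ccc(O)c([N+](=O)[O-])c1)SCc1ccc(Br)cc1)c1ccc(Br)cc1`: 10000 nM

All three numbers come from a functional assay on DU-145 cells (Homo sapiens) for inhibition, read by trypan blue exclusion, with a stated time of 96 h; on this read-out higher numbers stand for weaker inhibition of growth and lower numbers for stronger inhibition of growth. Compound 1 stands at the top of this small set, which makes it the weakest of the three, and its gaps to compound 3 and compound 2 both lie beyond the usual scatter.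

The next compound to be tested, compound 4 `COc1ccccc1/C=C(/SCc1ccc(Cl)cc1)C(=O)c1ccc(Cl)cc1`, keeps the rest of compound 1 and changes one group: 2-methoxyphenyl in place of 3-methylthiophen-2-yl on a double-bonded chain carbon bound to a double-bonded chain carbon. Here 2-methoxyphenyl stands in place of 3-methylthiophen-2-yl on a double-bonded chain carbon bound to a double-bonded chain carbon.

For the measured compounds named here, no pair of measured compounds differs in only one place, so no direct comparison can guide the forecast. Going by the values given here, the only guide is the spread of values: compound 3 gives 10000 nM and compound 2 gives 1000 nM, both lower than the number for compound 1, although they also differ from it elsewhere. A drop beyond the scatter is therefore expected in this assay, meaning stronger inhibition of growth, but this expectation is uncertain. The expected change is a 4.2-fold lower number from compound 1 to compound 4 (0.62 log units; beyond the scatter). For compound 4 the estimated value is 12000 nM, with an expected range from 2500 nM to 50000 nM.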

Compound 4, concentration for 50% growth inhibition: 1000 nM
Compound 4: middle estimate off by 12-fold (1.08 log units), on the high side; measured number outside the range, below it.
By their numbers in this assay, from the lowest: compounds 2 and 4 (each within the scatter of the next); then compound 3; then compound 1.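

In this assay, for the compounds shown here, replacing 3-methylthiophen-2-yl with 2-methoxyphenyl gives a 50-fold lower number from compound 1 to compound 4 (1.70 log units; beyond the scatter), the first direct reading of a single change in this set, and it means much stronger inhibition of growth. This shows that the group on a double-bonded chain carbon bound to a double-bonded chain carbon can by itself shift the result well beyond the scatter, even though the leaving and entering groups have the same counts of hydrogen-bond donors and acceptors and neither carries a net charge. Nothing measured here explains the size of this step.

The swap alters several features together: a five-membered ring with one hetero atom gives way to a six-membered ring of carbon only, and a methyl group is exchanged for a methoxy group, so the compounds shown cannot assign the step to any one of these features. Also open, from the compounds shown here alone, is whether an unsubstituted phenyl ring or a pyridine ring at this place would retain the stronger inhibition of growth seen with 2-methoxyphenyl.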